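The compounds below may be only part of what the source reports. "The series", "measured", "known", "first", "only" and "open" are said of these compounds alone.

Notes on the series. Two compounds have numbers in a functional assay on SiHa cells (Homo sapiens) for antiproliferative activity, read by CCK-8 assay, with a stated time of 72 h; on this read-out higher numbers stand for weaker inhibition and lower numbers for stronger inhibition. Compound 1 `CCOC(=O)Oc1cc(-c2cncnc2-c2cc(OC)c(OC)c(OC)c2)ccc1OC` gives 1890 nM in this assay. Compound 2 `COc1cc(-c2ncncc2-c2ccc(SC)cc2)cc(OC)c1OC` gives 560 nM in this assay, the lower of the two numbers, and the gap up to compound 1 lies beyond the scatter, so compound 2 is the stronger of the two measured compounds. Among the compounds with values here, no pair of measured compounds differs in one place, so no single step has been read yet.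

The next compound, compound 3 `COc1cc(-c2ncncc2-c2ccc(Br)cc2)cc(OC)c1OC`, departs from compound 2 at one point: bromo in place of methylsulfanyl on an aromatic carbon. Nothing measured in this set speaks to such a swap, so the direction of the step is open. Bromo in place of methylsulfanyl at this point is expected to give a modest step in this assay, a 1.8-fold higher number from compound 2 to compound 3 (0.25 log units; within the scatter), most likely toward a somewhat higher number. Compound 3 is therefore estimated at 1000 nM in this assay, with a range from 300 nM to 4000 nM.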

Compound 3, half-maximal inhibitory concentration: 2960 nM
For compound 3 the middle estimate is 3.0-fold (0.47 log units) below the measured one, and the stated range covers the measured number.
By their numbers in this assay, from the lowest: compound 2; then compounds 1 and 3 (each within the scatter of the next).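

In this assay, the step from methylsulfanyl to bromo gives a 5.3-fold higher number from compound 2 to compound 3 (0.72 log units; beyond the scatter), the first single-place step read in this series. It shows that this aromatic carbon, para to a large group, is sensitive to its substituent, and that 4-(methylsulfanyl)phenyl outperforms 4-bromophenyl here, so a bromo group cannot stand in for methylsulfanyl at this point without a loss of inhibition. No measurement offered here accounts for the size of this step.

Still open, on these data alone, is whether an amine or a carboxylic acid on this carbon, or a longer chain on the sulfur such as ethylsulfanyl, would match or improve on compound 2. As far as these compounds go, the reading also rests on a single pair, so whether the same swap gives a similar step on the core of compound 1 remains unknown.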